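Removing the Methoxy Group from Compound 3

The source may report more compounds than this note shows. Statements on the series, on what has been measured and on what is new or still open speak of the compounds shown alone.

Within the data shown here, compound 3 `COc1ccc(C(=O)NCc2ccc(CNS(=O)(=O)c3ccccc3)cc2)cc1` stands at the top of the three numbers measured so far. In an assay on MDA-MB-231 cells for binding affinity to C-X-C chemokine receptor type 4 (Homo sapiens), read by immunofluorescence and microscopy, with stated times of 10 min and 30 min (on this read-out lower numbers stand for an effect already at smaller amounts and higher numbers for an effect only at larger amounts of compound), compound 3 gives 1000 nM, whereas compound 1 `O=C(NCc1ccc(CNS(=O)(=O)c2ccccc2)cc1)c1ccncc1` gives 10 nM and compound 2 `O=C(NCc1ccc(CNS(=O)(=O)c2ccccc2)cc1)c1c(Cl)cc(Cl)cc1Cl` gives 10 nM. The step of a 100-fold higher number from compound 1 to compound 3 (2.00 log units; beyond the scatter) and the step of a 100-fold higher number from compound 2 to compound 3 (2.00 log units; beyond the scatter) are both large and beyond the scatter, while no change at the digits printed from compound 1 to compound 2 (within the scatter) lies within it.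

Compound 4 `O=C(NCc1ccc(CNS(=O)(=O)c2ccccc2)cc1)c1ccccc1` has not yet been measured in this assay. It differs from compound 3 by hydrogen in place of methoxy on an aromatic carbon. Among the measured compounds shown here, no measured step removes exactly this group. For the measured compounds named here, the steps that bear on it are those leading into compound 3, a 100-fold higher number from compound 1 to compound 3 (2.00 log units; beyond the scatter) and a 100-fold higher number from compound 2 to compound 3 (2.00 log units; beyond the scatter), which show that both other groups on the carbonyl carbon sit far lower than the 4-methoxyphenyl of compound 3. Phenyl shares with compound 3 everything but the methoxy, and it shares with compound 1 and compound 2 the absence of that group, so the number is expected to come down, probably only partway back toward compound 1 and compound 2. Such a drop is expected, namely a 33-fold lower number from compound 3 to compound 4 (1.52 log units; beyond the scatter). Compound 4 is therefore expected to give 30 nM in this assay, with a range from 3 nM to 300 nM.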

Compound 4, effective concentration (reported as EC, without a stated level of effect): 1 nM
Compound 4: middle estimate off by 30-fold (1.48 log units), on the high side, and the stated range ends above it.
By their numbers in this assay, from the lowest: compound 4; then compounds 1 and 2 (each within the scatter of the next); then compound 3.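

Taking the methoxy off the aromatic carbon, para to a large group, does more than close the gap to the other compounds: in this assay there is a 1000-fold lower number from compound 3 to compound 4 (3.00 log units; beyond the scatter), a step larger than any seen before at this position. Phenyl also separates from the two groups that had matched each other, with a 10-fold lower number from compound 2 to compound 4 (1.00 log units; beyond the scatter) and a 10-fold lower number from compound 1 to compound 4 (1.00 log units; beyond the scatter), so those earlier compounds did not mark the low end of this position, and among the four groups on the carbonyl carbon neither pyridin-4-yl nor 2,4,6-trichlorophenyl improves on plain phenyl, while 4-methoxyphenyl stands far apart from the other three. Nothing at hand accounts for these differences.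

The compounds shown leave open whether the large rise belongs to methoxy alone or to any group at that place, which a methyl, a fluorine or an amine there would help to separate. They also leave open which of the three chlorines of 2,4,6-trichlorophenyl carries its gap to phenyl.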